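Shortening the hydroxycarbamoyl chain of compound 2

The compounds below may be only part of what the source reports. "The series", "measured", "known", "first", "only" and "open" are said of these compounds alone.

Measured so far in a functional assay on HepG2 cells (Homo sapiens) for inhibition, read by MTT assay, with a stated time of 72 h; a higher number here means a weaker inhibitor, a lower number a stronger inhibitor:
Compound 1 `Nc1ncnc2c1c(-c1cnc3[nH]ccc3c1)nn2CCCCCCC(=O)NO`: 10300 nM
Compound 2 `Nc1nc2cc(-c3nn(CCCCCCCCC(=O)NO)c4ncnc(N)c34)ccc2o1`: 2610 nM

Of these two measurements, compound 2 gives the lower number, and its gap to compound 1 lies beyond the usual scatter. That makes compound 2 the stronger inhibitor of the pair in this assay.

The next compound to be considered is compound 3 `Nc1nc2cc(-c3nn(CCCCCCC(=O)NO)c4ncnc(N)c34)ccc2o1`, which differs from compound 2 in one place: hydroxycarbamoyl in place of 2-(hydroxycarbamoyl)ethyl on a saturated chain carbon, six bonds along the chain from an aromatic nitrogen. In words, hydroxycarbamoyl stands in place of 2-(hydroxycarbamoyl)ethyl on a saturated chain carbon, six bonds along the chain from an aromatic nitrogen.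

Within the data shown here, no two measured compounds differ in only one place, so the effect of this change has not been observed directly. The expectation therefore starts from compound 2 at 2610 nM, and a modest move towards a higher number, meaning a weaker inhibitor, seems most likely. The expected change is a 1.5-fold higher number from compound 2 to compound 3 (0.19 log units; within the scatter), although a result within the scatter would not be surprising. For compound 3 the estimated value is 4000 nM, with an expected range from 1500 nM to 11000 nM.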

Compound 3, half-maximal inhibitory concentration: 1610 nM
Compound 3: the middle estimate sits 2.5-fold (0.40 log units) above what was measured; low and high end bracket the measured number.
By their numbers in this assay, from the lowest: compounds 3 and 2 (each within the scatter of the next); then compound 1.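

In this assay, putting hydroxycarbamoyl in place of 2-(hydroxycarbamoyl)ethyl on a saturated chain carbon, six bonds along the chain from an aromatic nitrogen, gives a 1.6-fold lower number from compound 2 to compound 3 (0.21 log units; within the scatter), so compound 2 and compound 3 cannot be told apart and this chain position tolerates the change in length seen here. Compound 3 also shares its chain with compound 1, which isolates the exchange of the group on the aromatic carbon, a group of 10 heavy atoms in place of one of 9, and this single change gives a 6.4-fold lower number from compound 1 to compound 3 (0.81 log units; beyond the scatter), a gap that the earlier pair, differing in two places, could not assign to either place. Nothing at hand explains either step.

As far as these compounds go, whether a chain shorter than that of compound 3 would still leave the number in the same range stays open, as does the effect of a carboxylic acid in place of hydroxycarbamoyl at the chain end. From the compounds shown here alone, it is equally open whether the step on the aromatic carbon would have the same size with the 2-(hydroxycarbamoyl)ethyl-extended chain of compound 2.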